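The compounds below may be only part of what the source reports. "The series", "measured", "known", "first", "only" and "open" are said of these compounds alone.

Measured so far:
- compound 1 `FC(F)(F)c1cccc2cc(-c3nn[nH]n3)cnc12`, which in a functional assay on the whole organism (strain Sprague-Dawley) for inhibition, with Rattus norvegicus as the target (a higher number here means that more compound is needed for the effect, a lower number that less compound is needed), gives 25 mg/kg
- compound 2 `O=C(O)c1cnc2c(C(F)(F)F)cccc2c1`, which in this assay gives 75 mg/kg

For the measured compounds named here, compound 2 has the higher of the two numbers, so more of it is needed; the single step between the two, a 3.0-fold higher number from compound 1 to compound 2 (0.48 log units; beyond the scatter), is the only comparison available. Compound 3 `CCOc1cccc2cc(C(=O)O)cnc12` keeps the carboxy group of compound 2 and alters a different position: ethoxy in place of trifluoromethyl on an aromatic carbon. Going by the values given here, the one measured step concerns the group carrying the acid, not the position changed here, so no measured step bears on this change. With nothing to rest on, no step beyond the scatter is expected in either direction, and compound 3 is expected to sit near the number of compound 2, 75 mg/kg, with a wide range: no change at the digits printed from compound 2 to compound 3 (within the scatter). The estimate for compound 3 is thus 75 mg/kg, between 25 mg/kg and 220 mg/kg.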

Compound 3, minimum effective dose: > 50 mg/kg
Compound 3: only a limit was reported (the forecaster's own chance of this, stated with the estimate: 10%); the middle value does not contradict the limit.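

In this assay, for the compounds shown here, compound 3 gives > 50 mg/kg, which is a limit and not a number, so no step from compound 2 to compound 3 can be read. The compounds shown leave open how ethoxy in place of trifluoromethyl on an aromatic carbon changes the dose needed.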